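The compounds below may be only part of what the source reports. "The series", "measured", "known", "first", "only" and "open" are said of these compounds alone.

Measured compounds:
compound 1, `CC(C)=CC(=O)Nc1cccc(Oc2nc(Nc3cccc(C#N)c3)nc3c2CSCC3)c1`
compound 2, `CC(C)/C=C/C(=O)Nc1cccc(Oc2nc(Nc3cccc(C#N)c3)nc3c2CSCC3)c1`
compound 3, `COc1ccc(Nc2nc3c(c(Oc4cccc(NC(=O)C=C(C)C)c4)n2)CSCC3)cc1`

In a functional assay on MCF7 cells (Homo sapiens) for antiproliferative activity, read by MTT assay, with a stated time of 72 h (on this read-out higher numbers stand for weaker inhibition and lower numbers for stronger inhibition), compound 1 gives > 50000 nM, which is a limit of the assay rather than a number. Compound 2 gives 29600 nM in this assay. Compound 3 gives > 50000 nM in this assay, again a limit of the assay and not a number.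

Compound 2 differs from compound 1 by 3-methylbut-1-en-1-yl in place of 2-methylprop-1-en-1-yl on a carbonyl carbon. That change made an at least 1.6-fold lower number from compound 1 to compound 2 (0.22 log units; that floor lies within the scatter). Compound 3 differs from compound 1 in the core, by 4-methoxyphenyl in place of 3-cyanophenyl on a nitrogen on an aromatic ring. The step that the two limits leave unreadable from compound 1 to compound 3 cannot be sized, because of the limit of > 50000 nM in this assay, at which 2 of the 3 values shown sit.

Compound 4, `COc1ccc(Nc2nc3c(c(Oc4cccc(NC(=O)/C=C/C(C)C)c4)n2)CSCC3)cc1`, has not yet been measured in this assay. It differs from compound 3 by 3-methylbut-1-en-1-yl in place of 2-methylprop-1-en-1-yl on a carbonyl carbon, the same change as from compound 1 to compound 2, and the place around it is described in the same words in both pairs. Beside the earlier step of an at least 1.6-fold lower number from compound 1 to compound 2 (0.22 log units; that floor lies within the scatter), the step from compound 3 to compound 4 in this assay is expected to be an at least 1.1-fold lower number from compound 3 to compound 4 (0.04 log units; that floor lies within the scatter). This expectation rests on the step of an at least 1.6-fold lower number from compound 1 to compound 2 (0.22 log units; that floor lies within the scatter), which lies within the scatter. Compound 4 is therefore estimated at 45000 nM, most likely between 20000 nM and 100000 nM, with a real chance that this assay reports only a limit for it.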

Compound 4, half-maximal inhibitory concentration: > 50000 nM
Compound 4: a limit, no number; the forecaster's own chance of this, stated with the estimate: 60%; middle value at least 1.1-fold (0.04 log units) away from the limit.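

In this assay compound 4 gives > 50000 nM, which is a limit of the assay and not a number. The step from compound 3 to compound 4 cannot be read, so the exchange of 2-methylprop-1-en-1-yl for 3-methylbut-1-en-1-yl on the carbonyl carbon is neither shown to carry over from the 3-cyanophenyl compounds to the 4-methoxyphenyl compounds nor shown to fail there, because both values of that pair are limits: the limit of > 50000 nM in this assay, at which 3 of the 4 values shown sit. What can be read is that, with 3-methylbut-1-en-1-yl in place on both sides, 4-methoxyphenyl in place of 3-cyanophenyl gives an at least 1.6-fold higher number from compound 2 to compound 4 (0.22 log units; that floor lies within the scatter), so this pair neither establishes nor rules out a real difference.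

Among the compounds shown, only compound 2 has a number in this assay, at 29600 nM, which leaves no readable pair with which to compare the exchange on the two cores. On these data alone, it remains open whether a longer chain, or a chain bearing an amine or a carboxylic acid, in place of 3-methylbut-1-en-1-yl on the carbonyl carbon would give numbers on both cores and so allow that comparison.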